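The compounds below may be only part of what the source reports. "The series", "measured", "known", "first", "only" and "open" are said of these compounds alone.

Compound 1 `CC#CCn1c(N2CCC[C@@H](N)C2)cc(=O)n(Cc2ccc3ccc(Cl)cc3n2)c1=O` and compound 2 `CC#CCn1c(N2CCC[C@@H](N)C2)cc(=O)n(Cc2ccccc2)c1=O` share one core and were both tested in an assay on isolated protein for inhibition of Dipeptidyl peptidase 9 (Homo sapiens); on this read-out lower numbers stand for stronger inhibition and higher numbers for weaker inhibition. In this assay compound 1 gives only a limit, > 100000 nM, not a number. Compound 2 likewise gives only a limit in this assay, > 100000 nM. Compound 2 therefore stands at the edge of what the measurement can report, as does compound 1, which is what the limit of > 100000 nM in this assay, at which 2 of the 2 values shown sit, shows. Compound 3 `CC#CCn1c(N2CCC[C@@H](N)C2)cc(=O)n(CC#CC)c1=O` has not yet been measured. It differs from compound 2 in one place: prop-1-yn-1-yl in place of phenyl on a saturated chain carbon bound to an aromatic nitrogen, so that the benzyl group of compound 2 becomes a but-2-yn-1-yl group. Within the data shown here, no measured step covers this exchange, so the expectation for compound 3 rests only on compound 2 sitting at the limit. Compound 3 is expected to stay at that limit, with an expected step that the limit leaves unreadable from compound 2 to compound 3 and nothing beyond the scatter. The estimate for compound 3 in this assay is 150000 nM, within a range from 30000 nM to 600000 nM.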

Compound 3, half-maximal inhibitory concentration: > 100000 nM
Compound 3: only a limit was reported; the forecaster's own chance of this, stated with the estimate: 85%; the middle value is on the limit's open side.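

No step can be read from compound 2 to compound 3 in this assay, because compound 3, like compound 2, gives only a limit: the limit of > 100000 nM in this assay, at which 3 of the 3 values shown sit.

The compounds shown leave open how strongly each one inhibits the enzyme, and whether benzyl or but-2-yn-1-yl makes any difference.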